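Para-chloro on the urea phenyl: compound 2 to compound 4

The source may hold more compounds than are shown below. What is called first, only, known or untested is meant among the compounds shown, and "the series" means these compounds.

Of the compounds shown here, three of one series have been measured in a functional assay on NCI-H460 cells (Homo sapiens) for cytotoxicity, read by MTT assay, with a stated time of 72 h; on this read-out higher numbers stand for weaker inhibition and lower numbers for stronger inhibition. Compound 1 `CN(C)CCCNc1nc(-c2ccc(NC(=O)Nc3ccccc3Cl)cc2)nc2ccsc12` gives 430 nM. Compound 2 `CN(C)CCNc1nc(-c2ccc(NC(=O)Nc3ccccc3)cc2)nc2ccsc12` gives 640 nM, which places it second highest of the three numbers, a step within the scatter of compound 1 and an equally small step from compound 3. Compound 3 `CN(C)CCCNc1nc(-c2ccc(NC(=O)Nc3ccc(Cl)cc3Cl)cc2)nc2c(Cl)c(Cl)sc12` gives 980 nM, so none of the three can be told apart beyond the usual scatter of this assay.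

The next compound, compound 4 `CN(C)CCNc1nc(-c2ccc(NC(=O)Nc3ccc(Cl)cc3)cc2)nc2ccsc12`, differs from compound 2 by chloro in place of hydrogen on an aromatic carbon. For the measured compounds named here, no pair among the measured compounds differs in only this one place, so the size of this step is not yet known from a direct comparison. Going by the values given here, since every chloro-bearing compound measured so far sits within the scatter of compound 2, the step is expected to be small, in either direction or none at all; the expected step is a 1.3-fold lower number from compound 2 to compound 4 (0.11 log units; within the scatter). Compound 4 is estimated to give 500 nM, with a range from 200 nM to 1400 nM, because compound 1 gives 430 nM and compound 3 gives 980 nM.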

Compound 4, half-maximal inhibitory concentration: 130 nM
Estimate against measurement, compound 4: 3.8-fold (0.59 log units) above; measured number below the stated range.
By their numbers in this assay, from the lowest: compound 4; then compounds 1, 2 and 3 (each within the scatter of the next, the first and the last beyond it).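

In this assay, for the compounds shown here, the change from phenyl to 4-chlorophenyl gives a 4.9-fold lower number from compound 2 to compound 4 (0.69 log units; beyond the scatter), the first step that can be read at a single place, and it lies beyond the scatter. Going by these compounds alone, it shows that this position, on the aromatic ring of the urea and para to a large group, responds to one added chlorine atom, something the earlier compounds could not show, as they differ from one another in more than one place. No evidence at hand accounts for the size of this step.

The compounds shown leave open whether fluoro, bromo, methyl or methoxy at this same position would give a similar step. They also leave open whether the step from phenyl to 4-chlorophenyl persists on a core carrying a longer dimethylamino chain.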